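Acetyl for ethyl on the piperazine of a trimethoxyphenyl amide

The source may hold more compounds than are shown below. What is called first, only, known or untested is meant among the compounds shown, and "the series" means these compounds.

Compound 1 `CCN1CCN(CC(=O)N(Cc2ccc(OC)cc2)c2cc(OC)c(OC)c(OC)c2)CC1`, compound 2 `COc1ccc(CN(C(=O)CN2CCN(C(C)=O)CC2)c2cc(OC)c(OC)c(OC)c2)cc1` and compound 3 `CCN1CCN(C(=S)SCC(=O)N(Cc2ccc(OC)c(O)c2)c2cc(OC)c(OC)c(OC)c2)CC1` have been measured in a functional assay on MGC-803 cells (Homo sapiens) for inhibition, read by CCK-8 assay, with a stated time of 48 h; on this read-out higher numbers stand for weaker inhibition and lower numbers for stronger inhibition; compound 4 `COc1ccc(CN(C(=O)CSC(=S)N2CCN(C(C)=O)CC2)c2cc(OC)c(OC)c(OC)c2)cc1O` has not. In this assay compound 1 gives > 20000 nM, which is a limit of the assay and not a number, as noted in the limit of > 20000 nM in this assay, at which 1 of the 3 values shown sits. In this assay compound 2 gives 12800 nM, and compound 3 gives 380 nM. Compound 2 is set against compound 1 by acetyl in place of ethyl on an amine nitrogen in a ring; the step is an at least 1.5-fold lower number from compound 1 to compound 2 (0.19 log units; that floor lies within the scatter), read from a limit. The difference between the core of compound 3 and the core of compound 1 is not broken down here. Compound 4 is set against compound 3 by acetyl in place of ethyl on an amine nitrogen in a ring, the same change at the same place. Since the earlier step rests on a limit and its floor lies within the scatter, only a small movement is expected from compound 3 to compound 4: a 1.3-fold lower number from compound 3 to compound 4 (0.10 log units; within the scatter). Compound 4 is expected to come out near 300 nM, estimated to fall between 120 nM and 900 nM.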

Compound 4, half-maximal inhibitory concentration: 310 nM
The estimate for compound 4 lay 1.0-fold (0.01 log units) below the measured number, within the range that was stated.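

In this assay, the change from 4-ethylpiperazin-1-yl to 4-acetylpiperazin-1-yl gives a 1.2-fold lower number from compound 3 to compound 4 (0.09 log units; within the scatter), so on the core of compound 3 the two compounds stand within the scatter of each other. This is the second reading of the change in this series, and the two readings can be set side by side only in part: the same change on two cores in this assay, an at least 1.5-fold lower number (0.19 log units; that floor lies within the scatter) from compound 1 to compound 2 and a 1.2-fold lower number (0.09 log units; within the scatter) from compound 3 to compound 4; the limit leaves it open whether they differ. For compound 1 the value > 20000 nM is a limit of the assay and not a number; the pair therefore shows that the change is tolerated on the core of compound 3, but not that it has the same size on both cores.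

The compounds shown leave open whether a different group on the same ring nitrogen, such as a methyl, a longer acyl chain or a carboxylic acid, would move the number beyond the scatter. Among the compounds shown here, the difference between the core of compound 1 and the core of compound 3 also remains unresolved, since no pair here isolates any single part of it.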